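Swapping the amine substituent: cyclopropyl to 4-hydroxybenzyl

The source may hold more compounds than are shown below. What is called first, only, known or untested is meant among the compounds shown, and "the series" means these compounds.

Measured compounds:
Compound 1 `COc1ccc(CCCNCc2c(OC)cc(Oc3cccc(Nc4ccccc4)c3)cc2OC)cc1` gives 3320 nM in a functional assay on HT-29 cells (Homo sapiens) for inhibition, read by MTT assay, with a stated time of 72 h; on this read-out lower numbers stand for stronger inhibition and higher numbers for weaker inhibition.
Compound 2 `COc1cc(Oc2cccc(Nc3ccccc3)c2)cc(OC)c1CNC(C)C` reaches only the limit > 20000 nM in this assay.
Compound 3 `COc1cc(Oc2cccc(Nc3ccccc3)c2)cc(OC)c1CNC1CC1` gives 12300 nM in this assay.

Among the two numbers that are not limits, compound 3 stands at the higher one, and its nearest neighbour is compound 1, which sits a clear step lower. The compounds share one core and differ only in the group on the amine nitrogen. Compound 4 `COc1cc(Oc2cccc(Nc3ccccc3)c2)cc(OC)c1CNCc1ccc(O)cc1` has not yet been measured; it arises from compound 3 by the change (4-hydroxybenzyl in place of cyclopropyl on an amine nitrogen).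

Among the measured compounds shown here, two measured steps bear on this. Replacing the 3-(4-methoxyphenyl)propyl group by a small alkyl ring gave a 3.7-fold higher number from compound 1 to compound 3 (0.57 log units; beyond the scatter), and replacing it by isopropyl gave an at least 6.0-fold higher number from compound 1 to compound 2 (0.77 log units; beyond the scatter), where compound 2 sits at the limit (the limit of > 20000 nM in this assay, at which 1 of the 3 values shown sits). Between the two small groups the step of an at least 1.6-fold lower number from compound 2 to compound 3 (0.21 log units; that floor lies within the scatter) is not clearly resolved. Since 4-hydroxybenzyl, like the group in compound 1, carries an aromatic ring, a lower number for compound 4 than for compound 3 is expected, roughly a 2.5-fold lower number from compound 3 to compound 4 (0.39 log units; beyond the scatter). Compound 4 is therefore estimated at 5000 nM, with a range from 1500 nM to 15000 nM.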

Compound 4, half-maximal inhibitory concentration: 2180 nM
Compound 4: middle estimate off by 2.3-fold (0.36 log units), on the high side; the measured number falls inside the stated range.
By their numbers in this assay, from the lowest: compounds 4 and 1 (each within the scatter of the next); then compound 3. At a limit, above all of these: compound 2.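

In this assay, a 5.6-fold lower number from compound 3 to compound 4 (0.75 log units; beyond the scatter) shows that the amine nitrogen tolerates far more than a small ring, and that 4-hydroxybenzyl, with its six-membered aromatic ring, is a clear gain over cyclopropyl. The long 3-(4-methoxyphenyl)propyl chain also proves unnecessary for this level of inhibition: a 1.5-fold lower number from compound 1 to compound 4 (0.18 log units; within the scatter) is a difference that cannot be told apart from repeat-to-repeat noise, so the shorter aromatic group and the longer one perform alike. Compound 2 gives only a limit of the assay, so an at least 9.1-fold lower number from compound 2 to compound 4 (0.96 log units; beyond the scatter) is a floor for the gain over isopropyl and not its true size.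

From the compounds shown here alone, what stays open is whether the aromatic ring alone accounts for the gain, or whether its hydroxyl also contributes. A plain benzyl group or a 4-methoxybenzyl group on the same nitrogen would separate the two.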